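The source may hold more compounds than are shown below. What is called first, only, known or untested is meant among the compounds shown, and "the series" means these compounds.

Compound 1, `COc1cc2c(Nc3nc4ccc(C(=O)Nc5c(C)cccc5Cl)cc4s3)ncnc2cc1OCCCN1CCC(C)CC1`, in a functional assay on NCI-H661 cells (Homo sapiens) for cytotoxicity, read by WST assay, with a stated time of 72 h; on this read-out higher numbers stand for weaker inhibition and lower numbers for stronger inhibition: 7900 nM
Compound 2, `CCN(CC)CCCOc1cc2ncnc(Nc3nc4ccc(C(=O)Nc5c(C)cccc5Cl)cc4s3)c2cc1OC`, in this assay: 11200 nM
Compound 3, `COc1cc2c(Nc3nc4ccc(C(=O)Nc5c(C)cc(C)cc5C)cc4s3)ncnc2cc1OCCCN1CCCCC1`, in this assay: 10000 nM

Among these three, compound 1 carries the lowest number, though compound 3 lies only a 1.4-fold higher number from compound 1 to compound 2 (0.15 log units; within the scatter) is the only single-place step in this set; it exchanges the amine on the chain and is a 1.4-fold higher number from compound 1 to compound 2 (0.15 log units; within the scatter), so it says nothing about the anilide ring that the new compound changes. Compound 4, `COc1cc2c(Nc3nc4ccc(C(=O)Nc5c(C)cccc5C)cc4s3)ncnc2cc1OCCCN1CCC(C)CC1`, differs from compound 1 in one place: methyl in place of chloro on an aromatic carbon. For the measured compounds named here, no measured pair isolates this exchange. The closest hint is compound 3, whose anilide ring carries methyl groups only and which sits within the scatter of compound 1 in this assay, but it also differs in other positions, so its value alone cannot be read as a step. He therefore expects compound 4 to give a number close to compound 1, with a step of about a 1.1-fold higher number from compound 1 to compound 4 (0.06 log units; within the scatter), no larger than the scatter in either direction. His estimate for compound 4 is 9000 nM, within a range from 4000 nM to 20000 nM.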

Compound 4, half-maximal inhibitory concentration: 72300 nM
For compound 4 the middle estimate is 8.0-fold (0.90 log units) below the measured one; measured number outside the range, above it.
By their numbers in this assay, from the lowest: compounds 1, 3 and 2 (each within the scatter of the next); then compound 4.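

Within this assay, the exchange of chloro for methyl on an aromatic carbon, ortho to a large group, gives a 9.2-fold higher number from compound 1 to compound 4 (0.96 log units; beyond the scatter) and is the first single-place step at this ring, whereas the only earlier step, a 1.4-fold higher number from compound 1 to compound 2 (0.15 log units; within the scatter), changed the amine on the chain. It shows that the number at this position can depend on a single-group exchange, even though chloro and methyl both count one heavy atom and neither carries a hydrogen-bond donor or acceptor. Nothing available here accounts for the size of this step.

From the compounds shown here alone, it remains open whether bromo, fluoro, methoxy or plain hydrogen at this place would stay with chloro or go with methyl. Also open, going by these compounds, is whether the same exchange gives a similar step with diethylamino on the chain in place of 4-methylpiperidin-1-yl.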